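A few compounds are considered here, and "the series" means these few. Any claim that something is new, unique, unknown or untested is made for them only; others in the source may bear on it.

Compound 2 `CC(C(=O)NCc1ccc(C(C)(C)C)cc1OCc1ccc(F)cc1)c1ccc(NS(C)(=O)=O)c(F)c1` gives 3.8 nM in an assay on cells for antagonist activity at transient receptor potential cation channel subfamily V member 1 (Homo sapiens), read by FLIPR and calcium flux, with a stated time of 6 min (on this read-out lower numbers stand for stronger inhibition and higher numbers for weaker inhibition), which is the higher of the two numbers recorded so far; compound 1 `CCCCCCOc1cc(C(C)(C)C)ccc1CNC(=O)C(C)c1ccc(NS(C)(=O)=O)c(F)c1` gives 0.5 nM, and the step of a 7.6-fold higher number from compound 1 to compound 2 (0.88 log units; beyond the scatter) separates them. Compound 3 `CC(C(=O)NCc1ccc(C(C)(C)C)cc1SC1CCCCC1)c1ccc(NS(C)(=O)=O)c(F)c1` has not yet been measured. It differs from compound 2 by cyclohexylsulfanyl in place of (4-fluorobenzyl)oxy on an aromatic carbon. Within the data shown here, the only measured step that touches this position is a 7.6-fold higher number from compound 1 to compound 2 (0.88 log units; beyond the scatter), in which a saturated chain gave way to an aromatic ring and the number rose beyond the scatter. Among the measured compounds shown here, the change leading to compound 3 reverses that in one respect, since a non-aromatic ring replaces the aromatic one, but it also puts sulfur in place of oxygen and drops the saturated chain carbon that carried the ring; for these two features no measured step exists. On balance a modest fall in the number is expected, a 2.1-fold lower number from compound 2 to compound 3 (0.32 log units; beyond the scatter), without a full return to the level of compound 1. Compound 3 is therefore estimated at 1.8 nM in this assay, with a range from 0.5 nM to 7 nM.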

Compound 3, inhibition constant: 7.4 nM
The estimate for compound 3 lay 4.1-fold (0.61 log units) below the measured number; the whole stated range lies below it.
By their numbers in this assay, from the lowest: compound 1; then compounds 2 and 3 (each within the scatter of the next).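

In this assay, the swap at this position gives a 1.9-fold higher number from compound 2 to compound 3 (0.29 log units; within the scatter), so cyclohexylsulfanyl and (4-fluorobenzyl)oxy cannot be told apart here, even though they differ in ring type, in the atom bound to the aromatic carbon and in the presence of the fluorine. Against the open chain, the picture is clearer: the change gives a 15-fold higher number from compound 1 to compound 3 (1.17 log units; beyond the scatter), and with the earlier step of a 7.6-fold higher number from compound 1 to compound 2 (0.88 log units; beyond the scatter) this leaves compound 1, with its hexyloxy group, as the most potent of the three, with both ring-bearing groups on the weaker side of it. Nothing available explains why the two ring-bearing groups read alike or why the hexyloxy compound stands apart.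

The compounds shown leave open how much of the gap between compound 1 and compound 3 belongs to the ring and how much to the sulfur, since these two features change together; a hexylsulfanyl or a cyclohexyloxy group at this position would separate them. They also leave open how the number responds to chain length, as with a butoxy or octyloxy group, or to an amine at the end of the chain.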